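The source may hold more compounds than are shown below. What is called first, only, known or untested is meant among the compounds shown, and "the series" means these compounds.

Of the compounds shown here, two have been tested in a functional assay on the whole organism (spleen, spleen) with Rattus norvegicus as the target; a lower number here means that less compound is needed, a higher number that more compound is needed for the effect. Compound 1, `CCCCCCCOc1ccc(CC[C@@](N)(CO)CCO)cc1`, has the lower of the two numbers: in this assay compound 1 gives 0.018 mg/kg. Compound 2, `CCCCCCCCc1ccc(CCC(N)(CO)CCO)cc1`, has the higher number; in this assay compound 2 gives 0.12 mg/kg, and the gap between compound 1 and compound 2 lies beyond the usual scatter. Compound 2 therefore stands at the top of the two numbers recorded so far, which means that more of it is needed for the same effect than of compound 1.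

Compound 3, `CCCCCCCCc1ccc(CCC(C)(N)CCO)cc1`, has not yet been measured. It differs from compound 2 in a single place: hydrogen in place of hydroxy on a saturated chain carbon, two bonds along the chain from an amine nitrogen. Everything else in the molecule is unchanged.

Among the measured compounds shown here, no pair of measured compounds differs in exactly this way, so the size of this step cannot be read from the data. With the hydroxy removed, the number for compound 3 is expected to move upward, by a step of a 2.9-fold higher number from compound 2 to compound 3 (0.46 log units; beyond the scatter) that would lie beyond the scatter. Compound 3 is therefore estimated at 0.35 mg/kg, with a likely range from 0.1 mg/kg to 1.5 mg/kg.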

Compound 3, dose for 50% inhibition: > 10 mg/kg
Compound 3: no number, only a limit; the forecaster's own chance of this, stated with the estimate: 10%; middle value at least 28-fold (1.45 log units) away from the limit.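

Taking away one hydroxy, so that hydroxymethyl becomes methyl on a saturated chain carbon, two bonds along the chain from an amine nitrogen, is a large change in this assay: the data give an at least 83-fold higher number from compound 2 to compound 3 (1.92 log units; beyond the scatter). Compound 3 gives > 10 mg/kg, which is a limit of the assay and not a number: the limit of > 10 mg/kg in this assay, at which 1 of the 3 values shown sits. Among the compounds shown here, the earlier compounds differ from each other in more than one place, so this pair gives the first reading of a single change, and it shows that in this pair the effect depends heavily on the hydroxymethyl at this carbon, with far more compound needed once it has become methyl.

As far as these compounds go, whether a methoxymethyl or an aminomethyl group at this place would keep the effect remains open, as does whether the same change would cost as much on the core of compound 1. The compounds shown record the size of this large step. They do not explain it.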